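The compounds below may be only part of what the source reports. "The series", "measured", "known", "first", "only" and "open" are said of these compounds alone.

Three compounds share one core and differ at the outer ring of the urea. Compound 1, `O=C(Nc1cccc(-n2cc(-c3ccncc3)c(-c3cc(O)cc(Cl)c3)n2)c1)Nc1ccc(Cl)c(C(F)(F)F)c1`, gives 91% in a functional assay on MCF7 cells (Homo sapiens) for inhibition, read by sulforhodamine B assay, with a stated time of 48 h, tested at 1 uM; a higher number here means a weaker effect of the compound at the concentration tested, a lower number a stronger effect. Compound 2, `O=C(Nc1cccc(-n2cc(-c3ccncc3)c(-c3cc(O)cc(Cl)c3)n2)c1)Nc1ccc(Cl)c(Cl)c1`, gives 91% in this assay, and the step of no change at the digits printed from compound 1 to compound 2 (within the scatter) shows that chloro in place of trifluoromethyl on an aromatic carbon leaves the number where it was. Compound 3, `COc1cc(Cl)cc(-c2nn(-c3cccc(NC(=O)Nc4ccc(Cl)c(Cl)c4)c3)cc2-c2ccncc2)c1`, gives 83%, and the step of a number 8 percentage points lower from compound 2 to compound 3 (within the scatter), methyl in place of hydrogen on an oxygen on an aromatic ring, is also within the scatter. Compound 3 thus has the lowest of the three numbers, but its nearest neighbour, compound 1, and its furthest, compound 2, both stand within the scatter of it, so none of the three can be set apart from the others.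

Compound 4, `COc1cc(Cl)cc(-c2nn(-c3cccc(NC(=O)c4cccc(C(F)(F)F)c4)c3)cc2-c2ccncc2)c1`, changes a different part of the molecule: 3-(trifluoromethyl)phenyl in place of (3,4-dichlorophenyl)amino on a carbonyl carbon. Neither measured step touches this carbonyl carbon or the (3,4-dichlorophenyl)amino group that leaves, so no direct guide exists; both measured steps were within the scatter, and all three numbers sit in a narrow, weak band. The step of a number 4 percentage points higher from compound 3 to compound 4 (within the scatter) is therefore expected to stay within the scatter. Compound 4 is expected to give about 87%, with a range from 70% to 100%, in this assay.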

Compound 4, a percentage reported as activity, at one concentration (the size of the read-out at that concentration, not a potency): 57%
Estimate against measurement, compound 4: 30 percentage points above; the measured number lies below the stated range.
By their numbers in this assay, from the lowest: compound 4; then compounds 3, 1 and 2 (each within the scatter of the next).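

For the compounds shown here, the carbonyl carbon is the first position where a change carries the number beyond the scatter: a number 26 percentage points lower from compound 3 to compound 4 (beyond the scatter) in this assay, whereas the changes on the outer ring and on the oxygen had both stayed within it. The change itself has several parts, as (3,4-dichlorophenyl)amino, with its nitrogen and its hydrogen-bond donor, gives way to 3-(trifluoromethyl)phenyl, which has neither, so the urea of compounds 1 to 3 becomes an amide-type link in compound 4 and the two chlorines are replaced by a trifluoromethyl group in the same step. Nothing shown here gives a reason for the move in the number.

The compounds shown do not separate the loss of the amino nitrogen from the exchange of ring substituents, and they do not tell whether the hydroxy group of compounds 1 and 2 would read the same as the methoxy group of compound 4 alongside this new group. As far as these compounds go, how a piperidine ring or a butyl chain on this carbonyl carbon would read in this assay also remains open.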